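Swapping the 3-(methoxymethoxy)phenyl of compound 2 for 4-chlorophenyl

The compounds below may be only part of what the source reports. "The series", "measured", "known", "first", "only" and "open" are said of these compounds alone.

Measured so far in an ADME assay on HEK293 cells (Homo sapiens) for inhibition, read by MTT assay, with a stated time of 3 days; on this read-out lower numbers stand for stronger inhibition and higher numbers for weaker inhibition:
compound 1 `C/C=C/COc1cc(/C=C\c2cc(OC)c(OC)c(OC)c2)ccc1OC`: 135000 nM
compound 2 `COCOc1cccc(/C=C/CCCOc2cc(/C=C\c3cc(OC)c(OC)c(OC)c3)ccc2OC)c1`: 30000 nM

Of the two, compound 2 holds the lower number at 30000 nM, while compound 1 stands higher at 135000 nM, a gap beyond the usual scatter. Compound 3 `COc1ccc(/C=C\c2cc(OC)c(OC)c(OC)c2)cc1OCCC/C=C/c1ccc(Cl)cc1` has not yet been tested. Set against compound 2, it differs by 4-chlorophenyl in place of 3-(methoxymethoxy)phenyl on a double-bonded chain carbon bound to a double-bonded chain carbon, with 4-chlorophenyl in place of 3-(methoxymethoxy)phenyl on a double-bonded chain carbon bound to a double-bonded chain carbon. The rest of the structure stays the same.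

Among the measured compounds shown here, no measured pair shows what such a swap does, so the expectation is a loose one. It rests on compound 2 at 30000 nM, the measured compound that also carries a phenyl group on a double-bonded chain carbon. No change beyond the scatter is expected in this assay, and the expected move, a 1.2-fold lower number from compound 2 to compound 3 (0.08 log units; within the scatter), is slightly downward at most. For compound 3 the estimated value is 25000 nM, with an expected range of 9000 nM to 70000 nM.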

Compound 3, half-maximal inhibitory concentration: 111000 nM
Beside the measured number, compound 3's estimate is 4.4-fold (0.65 log units) below it; the whole stated range lies below it.
By their numbers in this assay, from the lowest: compound 2; then compounds 3 and 1 (each within the scatter of the next).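

In this assay, among the compounds shown here, the change gives the first reading of what the aryl group on a double-bonded chain carbon bound to a double-bonded chain carbon can do: 4-chlorophenyl in place of 3-(methoxymethoxy)phenyl brings a 3.7-fold higher number from compound 2 to compound 3 (0.57 log units; beyond the scatter), so the two groups are not interchangeable here. The other step, a 1.2-fold lower number from compound 1 to compound 3 (0.09 log units; within the scatter), lies within the scatter: with 4-(4-chlorophenyl)but-3-en-1-yl in place of prop-1-en-1-yl on a saturated chain carbon bound to an oxygen on an aromatic ring, compound 3 cannot be told apart from compound 1, so a chain that ends in a phenyl ring does not by itself go with the lower number of compound 2. No data on hand offer an explanation for either step.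

The entering and leaving groups differ both in their substituent and in where it sits on the ring, so the compounds shown leave open which of the two matters. A 3-chlorophenyl or a 4-(methoxymethoxy)phenyl on the same chain would separate these, and a 3-hydroxyphenyl would test whether the whole methoxymethoxy group is needed.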